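The source may report more compounds than this note shows. Statements on the series, on what has been measured and on what is new or still open speak of the compounds shown alone.

Measured in a functional assay on SW-620 cells (Homo sapiens) for cytotoxicity, read by MTT assay, with a stated time of 72 h; on this read-out higher numbers stand for weaker inhibition and lower numbers for stronger inhibition:

compound 1, `COc1cccc(/C=C2\CCC/C(=C\c3ccccc3Cl)C2=O)c1OC`: 10300 nM
compound 2, `COc1cccc(/C=C2\CCC/C(=C\c3ccc(Cl)cc3)C2=O)c1OC`: 11100 nM
compound 3, `COc1ccccc1/C=C1\CCC/C(=C\c2cccc(OC)c2OC)C1=O`: > 20000 nM

Compound 3 stands apart from the other two in that this assay gives it only a limit, > 20000 nM, and not a number; the reading is the limit of > 20000 nM in this assay, at which 1 of the 3 values shown sits. The two chloro compounds sit close together, the step of a 1.1-fold higher number from compound 1 to compound 2 (0.03 log units; within the scatter). The steps that lead to compound 3 are an at least 1.9-fold higher number from compound 1 to compound 3 (0.28 log units; that floor lies within the scatter) and an at least 1.8-fold higher number from compound 2 to compound 3 (0.25 log units; that floor lies within the scatter), both of them only floors, so all that can be said is that the methoxy compound is at or beyond the weaker edge of what the chloro compounds show.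

Compound 4, `COc1cccc(/C=C2\CCC/C(=C\c3ccc(Cl)cc3Cl)C2=O)c1OC`, is the next step from compound 3: 2,4-dichlorophenyl in place of 2-methoxyphenyl on a double-bonded chain carbon bound to a double-bonded ring carbon. This change brings back both the chloro of compound 1 and the chloro of compound 2 on the same ring while removing the methoxy that accompanied the move to the limit. The two steps of an at least 1.9-fold higher number from compound 1 to compound 3 (0.28 log units; that floor lies within the scatter) and an at least 1.8-fold higher number from compound 2 to compound 3 (0.25 log units; that floor lies within the scatter) therefore bear on it in reverse, and a return toward the chloro compounds is expected. Compound 4 is expected to show a step of an at least 2.2-fold lower number from compound 3 to compound 4 (0.34 log units; beyond the scatter), back toward stronger inhibition. Compound 4 is estimated at 9000 nM, with a range from 3000 nM to 25000 nM.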

Compound 4, half-maximal inhibitory concentration: 16300 nM
Beside the measured number, compound 4's estimate is 1.8-fold (0.26 log units) below it; measured number inside the range.
By their numbers in this assay, from the lowest: compounds 1, 2 and 4 (each within the scatter of the next). At a limit, above all of these: compound 3.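

In this assay, the step of a 1.5-fold higher number from compound 2 to compound 4 (0.17 log units; within the scatter) and the step of a 1.6-fold higher number from compound 1 to compound 4 (0.20 log units; within the scatter) show that a second chloro on the aromatic ring gives a compound that cannot be told apart from either compound with one chloro. Putting 2,4-dichlorophenyl in place of 2-methoxyphenyl on a double-bonded chain carbon bound to a double-bonded ring carbon restores a measured number, but the step of an at least 1.2-fold lower number from compound 3 to compound 4 (0.08 log units; that floor lies within the scatter) is only a floor and does not establish a real separation. Compound 3 remains a limit and not a number: the limit of > 20000 nM in this assay, at which 1 of the 4 values shown sits.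

Going by these compounds, how far compound 3 truly lies from the three chloro compounds stays open. Also open, on these data alone, is whether an amine or a carboxylic acid on this aromatic ring would move the number beyond what the chloro compounds show.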